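Oxazolyl for ethoxy on the phenylpiperazine of compound 3

A few compounds are considered here, and "the series" means these few. Any claim that something is new, unique, unknown or untested is made for them only; others in the source may bear on it.

Three compounds carry the same aryl-piperazine linked through a three-carbon chain to an amino-substituted aromatic carboxamide. In a functional assay for antagonist activity at Alpha-1A adrenergic receptor (Oryctolagus cuniculus) (on this read-out higher numbers stand for weaker binding and lower numbers for tighter binding), compound 1 `COc1ccccc1N1CCN(CCCNc2nc(C)cc(C)c2C(N)=O)CC1` gives 10 nM. Compound 2 `COc1ccccc1N1CCN(CCCNc2cncnc2C(=O)N(C)C)CC1` gives 3.98 nM in this assay. Compound 3 `CCOc1ccccc1N1CCN(CCCNc2ncccc2C(=O)N(C)C)CC1` gives 0.501 nM in this assay, the lowest of the three numbers; the value of compound 2 stands higher by a gap beyond the scatter, and that of compound 1 stands higher still, also beyond the scatter.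

Compound 4 `CN(C)C(=O)c1cccnc1NCCCN1CCN(c2ccccc2-c2ncco2)CC1` has not yet been measured in this assay. It differs from compound 3 in one place: 1,3-oxazol-2-yl in place of ethoxy on an aromatic carbon. The ethoxy leaves and the 1,3-oxazol-2-yl enters on an aromatic carbon of a six-membered aromatic ring of carbon only, ortho to a large group.

Among the compounds with values here, no pair of measured compounds shows this exchange, so the size of the step cannot be read from the data at hand. A step of modest size toward a higher number, possibly no larger than the scatter, is expected from compound 3 to compound 4, a 3.0-fold higher number from compound 3 to compound 4 (0.48 log units; beyond the scatter). Compound 4 is therefore estimated at 1.5 nM in this assay, within a range from 0.3 nM to 8 nM.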

Compound 4, dissociation constant: 0.316 nM
Compound 4: the middle estimate sits 4.7-fold (0.68 log units) above what was measured, within the range that was stated.
By their numbers in this assay, from the lowest: compounds 4 and 3 (each within the scatter of the next); then compound 2; then compound 1.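

In this assay, putting 1,3-oxazol-2-yl in place of ethoxy on the aromatic carbon gives a 1.6-fold lower number from compound 3 to compound 4 (0.20 log units; within the scatter), so the number stays level within the scatter. Within the data shown here, no earlier pair differed in one place, which makes this the first single change that can be read in the set, and it shows that this position, ortho to a large group, accepts an aromatic five-membered ring with more heavy atoms and one more hydrogen-bond acceptor than ethoxy without a measurable change in this read-out. Nothing at hand accounts for the two groups reading alike.

The compounds shown leave open whether a 1,3-thiazol-2-yl or furan-2-yl ring, a phenyl ring, or an open group such as a nitrile or a longer alkoxy chain would stay at the same level at this position. They also leave open whether 1,3-oxazol-2-yl would give a similar result in place of the methoxy of compound 1 or compound 2, whose remaining parts differ from those of compound 3.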